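Swapping the Azole on the Piperazine Methylene

The source may report more compounds than this note shows. Statements on the series, on what has been measured and on what is new or still open speak of the compounds shown alone.

Within the data shown here, compound 3 `CCc1cc(CN2CCN(c3cccc4[nH]c(-c5ccc(C(C)(C)C)cc5)nc34)CC2)nn1C` gives 43 nM in an assay on isolated protein for displacement of a labelled ligand from Gonadotropin-releasing hormone receptor (Homo sapiens) (a lower number here means a stronger inhibitor, a higher number a weaker inhibitor), the highest of the three numbers measured so far. Compound 1 `Cc1nc(C)c(CN2CCN(c3cccc4[nH]c(-c5ccc(C(C)(C)C)cc5)nc34)CC2)s1` gives 27 nM in this assay, and the step of a 1.6-fold higher number from compound 1 to compound 3 (0.20 log units; within the scatter) stays within the scatter. Compound 2 `Cc1nc(CN2CCN(c3cccc4[nH]c(-c5ccc(C(C)(C)C)cc5)nc34)CC2)c(C)s1` gives 21 nM in this assay; the step of a 2.0-fold higher number from compound 2 to compound 3 (0.31 log units; beyond the scatter) is modest but beyond the scatter, while a 1.3-fold lower number from compound 1 to compound 2 (0.11 log units; within the scatter) is within it.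

Compound 4 `CCCn1cc(CN2CCN(c3cccc4[nH]c(-c5ccc(C(C)(C)C)cc5)nc34)CC2)nc1C` differs from compound 3 in one place: 2-methyl-1-propyl-1H-imidazol-4-yl in place of 5-ethyl-1-methyl-1H-pyrazol-3-yl on a saturated chain carbon bound to an amine nitrogen in a ring. Every measured step in this set exchanges one five-membered aromatic ring with two hetero atoms for another at that same position, and none of those exchanges shifted the number further than a 2.0-fold higher number from compound 2 to compound 3 (0.31 log units; beyond the scatter). The change leading to compound 4 is of the same kind, so in this assay a step no larger than that is expected, with no clear direction, and quite possibly none beyond the scatter. Compound 4 is therefore estimated at 35 nM, with a range from 15 nM to 90 nM, which corresponds to an expected step of a 1.2-fold lower number from compound 3 to compound 4 (0.09 log units; within the scatter).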

Compound 4, half-maximal inhibitory concentration: 18 nM
Compound 4: middle estimate off by 1.9-fold (0.29 log units), on the high side; low and high end bracket the measured number.
By their numbers in this assay, from the lowest: compounds 4, 2, 1 and 3 (each within the scatter of the next, the first and the last beyond it).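

In this assay, the exchange of 5-ethyl-1-methyl-1H-pyrazol-3-yl for 2-methyl-1-propyl-1H-imidazol-4-yl gives a 2.4-fold lower number from compound 3 to compound 4 (0.38 log units; beyond the scatter), which is modest but makes this the second step at this position beyond the scatter, and compound 3 again stands at its weaker end. The two thiazolyl comparisons, a 1.2-fold lower number from compound 2 to compound 4 (0.07 log units; within the scatter) and a 1.5-fold lower number from compound 1 to compound 4 (0.18 log units; within the scatter), both stay within the scatter, so the group with the propyl chain fits at this position with no measurable loss, and compounds 1, 2 and 4 cannot be ranked against one another. Nothing available explains why the imidazolyl and pyrazolyl compounds part in this way.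

The step from compound 3 to compound 4 changes the ring and its alkyl groups at once, so the compounds shown cannot separate the contribution of the imidazole ring from that of the propyl chain. They also leave open how a pyridine ring, a phenyl ring or a carboxylic acid on the ring would fare on a saturated chain carbon bound to an amine nitrogen in a ring.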